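Notes on aryl substitution in the cyclopropylmethyl series

The source may hold more compounds than are shown below. What is called first, only, known or untested is meant among the compounds shown, and "the series" means these compounds.

Measured so far:
compound 1, `Brc1cccc2c1nnn2CC1CC1`: 0.6 mL/min/g in an ADME assay on microsomes from liver (Rattus norvegicus, strain Wistar) for metabolic stability, tested at 2.5 uM; a lower number here means slower removal, a higher number faster removal of the compound
compound 2, `Fc1cccc2c1nnn2CC1CC1`: "not determined" (no result reported) in this assay

Compound 2 has no number in this assay, its entry reading "not determined" (no result reported); the only measured point in the series is compound 1, which gives 0.6 mL/min/g. Compound 3, `COc1cccc2c1nnn2CC1CC1`, differs from compound 2 by methoxy in place of fluoro on an aromatic carbon. For the measured compounds named here, with no measured step to lean on, the size of the change from compound 2 to compound 3 in this assay cannot be anchored; the working expectation is no step beyond the scatter, with the range left open on the faster side. Compound 3 is estimated at 1 mL/min/g, within 0.3 mL/min/g to 3 mL/min/g.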

Compound 3, intrinsic clearance in a liver preparation (reported as CLH), per the amount of preparation that the assay uses: 0.8 mL/min/g
Compound 3: the middle estimate sits 1.3-fold (0.10 log units) above what was measured; the measured number falls inside the stated range.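

Methoxy in place of bromo on this aromatic carbon gives a 1.3-fold higher number from compound 1 to compound 3 (0.12 log units; within the scatter) in this assay, the first measured step in the series. The two groups cannot be told apart in this read-out, so the position accepts methoxy, with its two heavy atoms and one hydrogen-bond acceptor, without a step beyond the scatter. Nothing at hand accounts for this result.

Compound 2 has no number, so steps to it cannot be read. Going by these compounds, how an amine or a carboxylic acid on this carbon would fare remains open.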